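Swapping Iodo for Trifluoromethyl on the Shared Core

This account rests on a few compounds, and the source may have more. Where it says the series, first, only, none or still open, it means among the compounds named here.

Measured compounds:
Compound 1 `O=c1[nH]c(=O)n([C@H]2C[C@@H]3O[PH](O)(O)OC[C@H]3O2)cc1Br` in a functional assay (Raji cells) for antiproliferative activity, with Homo sapiens as the target (a lower number here means a stronger inhibitor, a higher number a weaker inhibitor), gives 224 ug/mL.
Compound 2 `O=c1[nH]c(=O)n([C@H]2C[C@@H]3O[PH](O)(O)OC[C@H]3O2)cc1I` in this assay gives 54 ug/mL.

Among the two numbers known, compound 2 stands lowest, and its nearest neighbour is compound 1, as shown by a 4.1-fold lower number from compound 1 to compound 2 (0.62 log units; beyond the scatter). Among the measured compounds shown here, that single step is the only measured change available, and it concerns a halogen for a halogen at the same aromatic carbon.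

Compound 3 `O=c1[nH]c(=O)n([C@H]2C[C@@H]3O[PH](O)(O)OC[C@H]3O2)cc1C(F)(F)F` differs from compound 2 in one place: trifluoromethyl in place of iodo on an aromatic carbon. The step from compound 1 to compound 2 bears on this change only indirectly, since it replaced one halogen with another, whereas here a halogen gives way to a trifluoromethyl group at the same carbon. That step was modest in size and pointed toward lower numbers as the group at this position changed. For the measured compounds named here, no measured step shows what a trifluoromethyl group does here, so the direction is uncertain and a change within the scatter is as plausible as a step in either direction.

Compound 3 is therefore expected to give about 40 ug/mL in this assay, within a range from 8 ug/mL to 200 ug/mL, which amounts to an expected 1.4-fold lower number from compound 2 to compound 3 (0.13 log units; within the scatter).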

Compound 3, concentration for 50% inhibition: 1.81 ug/mL
For compound 3 the middle estimate is 22-fold (1.34 log units) above the measured one, and the stated range ends above it.
By their numbers in this assay, from the lowest: compound 3; then compound 2; then compound 1.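

In this assay, the group on this aromatic carbon turns out to count for far more than the exchange of one halogen for another had shown: trifluoromethyl in place of iodo brings a 30-fold lower number from compound 2 to compound 3 (1.47 log units; beyond the scatter), a large step where the earlier one, a 4.1-fold lower number from compound 1 to compound 2 (0.62 log units; beyond the scatter), was modest. Trifluoromethyl in place of bromo brings a 120-fold lower number from compound 1 to compound 3 (2.09 log units; beyond the scatter), so compound 3 is the strongest inhibitor of the three, and the order at this position runs from trifluoromethyl through iodo to bromo. Nothing available gives a measured property that would account for this large step.

On these data alone, it remains open whether the gain belongs to trifluoromethyl in particular, or whether a methyl, a nitrile or a carboxylic acid on the same carbon would give a similar number, and where chloro or fluoro would fall relative to bromo and iodo. As far as these compounds go, it also remains open whether the same order would hold on a different core or in cells other than those used here, since all three compounds share one core and one assay.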